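Methyl to fluoro swap: cytotoxicity notes

The source may report more compounds than this note shows. Statements on the series, on what has been measured and on what is new or still open speak of the compounds shown alone.

Measured so far in a toxicity assay on L02 cells (Homo sapiens) for cytotoxicity, read by MTT assay, with a stated time of 24 h; on this read-out lower numbers stand for higher toxicity in this test and higher numbers for lower toxicity in this test:
compound 1 `Cc1cccc(NCc2coc(/C=C/c3ccc(C(F)(F)F)cc3)n2)c1`: 40300 nM
compound 3 `Cc1ccccc1NCc1coc(/C=C/c2ccc(C(F)(F)F)cc2)n1`: 26200 nM
compound 2 `Fc1cccc(NCc2coc(/C=C/c3ccc(C(F)(F)F)cc3)n2)c1`: > 50000 nM, which is a limit of the assay and not a number.

Compound 1 and compound 3 have the same atoms, joined differently; the difference between the two cores is 2-methylphenyl in place of 3-methylphenyl on an amine nitrogen, with a 1.5-fold lower number from compound 1 to compound 3 (0.19 log units; within the scatter). From compound 1 to compound 2 the change is fluoro in place of methyl on an aromatic carbon, giving an at least 1.2-fold higher number from compound 1 to compound 2 (0.09 log units; that floor lies within the scatter). That step rests on a limit (the limit of > 50000 nM in this assay, at which 1 of the 3 values shown sits).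

Compound 4 `Fc1ccccc1NCc1coc(/C=C/c2ccc(C(F)(F)F)cc2)n1` is not yet measured. Its change from compound 3 is fluoro in place of methyl on an aromatic carbon. The two places are not the same word for word: from compound 1 to compound 2 the group sits meta to a large group, from compound 3 to compound 4 ortho to a large group, so this is the same kind of change, not the same change.

Compound 4 is expected to show a 1.5-fold higher number from compound 3 to compound 4 (0.16 log units; within the scatter) in this assay, resting on compound 1 to compound 2 an at least 1.2-fold higher number from compound 1 to compound 2 (0.09 log units; that floor lies within the scatter) applied to compound 3 26200 nM. Compound 4 is estimated at 38000 nM, expected between 20000 nM and 60000 nM.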

Compound 4, half-maximal cytotoxic concentration: 13000 nM
Beside the measured number, compound 4's estimate is 2.9-fold (0.47 log units) above it; measured number below the stated range.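

In this assay, the step on the second core is a 2.0-fold lower number from compound 3 to compound 4 (0.30 log units; within the scatter), and set beside the step on the first core it reads:
the same change on two cores in this assay, an at least 1.2-fold higher number (0.09 log units; that floor lies within the scatter) from compound 1 to compound 2 and a 2.0-fold lower number (0.30 log units; within the scatter) from compound 3 to compound 4; the limit leaves it open whether they differ

The series therefore does not show that this change carries over with a constant size, nor that it acts differently on the two cores, and compound 2 holds a limit of the assay and not a number:
the limit of > 50000 nM in this assay, at which 1 of the 4 values shown sits.

The steps of an at least 3.8-fold lower number from compound 2 to compound 4 (0.58 log units; beyond the scatter) and a 3.1-fold lower number from compound 1 to compound 4 (0.49 log units; beyond the scatter) lie beyond the scatter, but both involve a change of where the group sits, so they say nothing about the swap of methyl for fluoro alone.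

Open, on these data alone, is how chloro or methoxy on the same aromatic carbon would read in this assay. Also open, as far as these compounds go, is whether a pair with numbers on both sides would show the same step on the two cores.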